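A few compounds are considered here, and "the series" means these few. Any claim that something is new, unique, unknown or untested is made for them only; others in the source may bear on it.

Measured compounds:
compound 1, `O=c1ccoc2cc(OCc3cn(Cc4ccccc4)nn3)ccc12`, in a functional assay on HeLa cells (Homo sapiens) for cytotoxicity, read by MTT assay, with a stated time of 48 h (on this read-out higher numbers stand for weaker inhibition and lower numbers for stronger inhibition), gives > 100000 nM, which is a limit of the assay and not a number.
compound 2, `O=c1ccoc2cc(OCc3cn(Cc4ccc(Cl)cc4)nn3)ccc12`, gives 37600 nM.
compound 3, `Cc1ccccc1Cn1cc(COc2ccc3c(=O)ccoc3c2)nn1`, gives 15300 nM.

Compound 2 holds the highest of the two numbers recorded; compound 3 sits below it by a 2.5-fold lower number from compound 2 to compound 3 (0.39 log units; beyond the scatter), and compound 1 sits at the limit of > 100000 nM in this assay, at which 1 of the 3 values shown sits. Compound 4, `CC(C)(C)c1ccc(Cn2cc(COc3ccc4c(=O)ccoc4c3)nn2)cc1`, differs from compound 2 by tert-butyl in place of chloro on an aromatic carbon. Within the data shown here, no measured step exchanges one group for another at this carbon, so the nearest guide is the step of an at least 2.6-fold lower number from compound 1 to compound 2 (0.42 log units; beyond the scatter), which shows that filling this carbon with a substituent lowered the number, and the step of an at least 6.5-fold lower number from compound 1 to compound 3 (0.81 log units; beyond the scatter), which shows a second small group on the benzyl ring doing the same. Keeping the carbon occupied, the tert-butyl is expected to leave compound 2 roughly where it is or a little lower, a change of a 1.7-fold lower number from compound 2 to compound 4 (0.23 log units; within the scatter). Compound 4 is therefore estimated at 22000 nM, with a range of 7000 nM to 65000 nM.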

Compound 4, half-maximal inhibitory concentration: 17600 nM
Compound 4: middle estimate off by 1.3-fold (0.10 log units), on the high side, and the stated range covers the measured number.
By their numbers in this assay, from the lowest: compounds 3 and 4 (each within the scatter of the next); then compound 2. At a limit, above all of these: compound 1.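

In this assay, among these compounds, the exchange of chloro for tert-butyl on this aromatic carbon, para to a large group, gives a 2.1-fold lower number from compound 2 to compound 4 (0.33 log units; beyond the scatter), the first step that swaps one group for another at this carbon. Measured against hydrogen at the same carbon, tert-butyl gives an at least 5.6-fold lower number from compound 1 to compound 4 (0.75 log units; beyond the scatter), so the lower number seen with chloro is not lost with four heavy atoms in place of one, and it goes further. That second step gives only a bound and not a full size: the limit of > 100000 nM in this assay, at which 1 of the 4 values shown sits.

On these data alone, whether an amine or a carboxylic acid on this carbon would also keep the number low stays open. The compounds shown also do not tell whether a longer chain in place of tert-butyl would lower the number further.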